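The compounds below may be only part of what the source reports. "The series", "measured", "known", "first", "only" and "open" are said of these compounds alone.

Measured in a functional assay on MDA-MB-231 cells (Homo sapiens) for cytotoxicity, read by MTT assay, with a stated time of 48 h; a higher number here means a weaker inhibitor, a lower number a stronger inhibitor:
- Compound 1 `CCn1c(/C=C2/C(=O)Nc3ccc(F)cc32)nc2ccccc21`: > 50000 nM
- Compound 2 `Cn1c(/C=C2/C(=O)Nc3ccc([N+](=O)[O-])cc32)nc2ccccc21`: "not determined" (no result reported)
- Compound 3 `Cn1c(/C=C2/C(=O)Nc3ccc(Br)cc32)nc2ccccc21`: > 50000 nM

Compound 3 gives > 50000 nM, which is a limit of the assay and not a number. It stands at the limit of > 50000 nM in this assay, at which 2 of the 3 values shown sit. Compound 4 `Cn1c(/C=C2/C(=O)Nc3ccc(F)cc32)nc2ccccc21` has fluoro in place of bromo on an aromatic carbon. Going by the values given here, no measured pair shows this change alone. Compound 1 also carries fluoro and gives > 50000 nM, again a limit. No step beyond the scatter is therefore expected in this assay, in either direction. The expected step that the limit leaves unreadable from compound 3 to compound 4 stays within the scatter. Compound 4 is estimated at 60000 nM, with an expected range from 25000 nM to 100000 nM. A further limit is the likeliest report.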

Compound 4, half-maximal inhibitory concentration: 21700 nM
The estimate for compound 4 lay 2.8-fold (0.44 log units) above the measured number; the whole stated range lies above it.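

In this assay, fluoro in place of bromo on the aromatic carbon gives an at least 2.3-fold lower number from compound 3 to compound 4 (0.36 log units; beyond the scatter), so this position responds to the halogen it carries. Hydrogen in place of methyl on the saturated chain carbon bound to the aromatic nitrogen gives an at least 2.3-fold lower number from compound 1 to compound 4 (0.36 log units; beyond the scatter), so with fluoro in place, that chain matters as well. Both steps are minimum sizes, since each starts from a limit of the assay: the limit of > 50000 nM in this assay, at which 2 of the 4 values shown sit.

Going by these compounds, how chloro or an amine would read at this aromatic carbon remains open. So does the effect of a propyl chain on the aromatic nitrogen.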